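The source may hold more compounds than are shown below. What is called first, only, known or untested is meant among the compounds shown, and "the series" means these compounds.

In an assay for binding affinity, read by spectrophotometry (on this read-out lower numbers stand for stronger inhibition and higher numbers for weaker inhibition), compound 1 `C[C@H](CCCN1CCN(C)CC1)Nc1ccnc2cc(Cl)ccc12` gives 180000 nM, and compound 2 `C[C@H](CCCN1CCCCC1)Nc1ccnc2cc(Cl)ccc12` gives 130000 nM. Within the data shown here, compound 2 holds the lowest of the two numbers known so far, yet its nearest neighbour is compound 1, and the step of a 1.4-fold lower number from compound 1 to compound 2 (0.14 log units; within the scatter) lies within the scatter, so no order between the two can be claimed. Compound 3 `CCN(C)CCC[C@@H](C)Nc1ccnc2cc(Cl)ccc12` differs from compound 2 as follows: ethyl(methyl)amino in place of piperidin-1-yl on a saturated chain carbon, four bonds along the chain from a nitrogen on an aromatic ring. Among the measured compounds shown here, only the step from compound 1 to compound 2 bears on this change, since it varies the same group on the same saturated chain carbon, and that step was within the scatter. On that basis the step of a 1.1-fold higher number from compound 2 to compound 3 (0.03 log units; within the scatter) is expected to stay within the scatter as well, with no clear direction. Compound 3 is therefore estimated to give 140000 nM in this assay, in a range from 60000 nM to 320000 nM.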

Compound 3, half-maximal inhibitory concentration: 140000 nM
The estimate for compound 3 equals the measured number at the digits printed; measured number inside the range.
By their numbers in this assay, from the lowest: compounds 2, 3 and 1 (each within the scatter of the next).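

In this assay, the step of a 1.1-fold higher number from compound 2 to compound 3 (0.03 log units; within the scatter) shows that a group with no ring, ethyl(methyl)amino, reads within the scatter of the six-membered ring of piperidin-1-yl at this saturated chain carbon. The step of a 1.3-fold lower number from compound 1 to compound 3 (0.11 log units; within the scatter) is also within the scatter, so all three groups at this place now lie within the scatter of one another, whether or not they carry a ring, and no order among them can be claimed. No supporting data are available to explain this result.

On these data alone, every step seen at this place remains within the scatter, so it is still open whether any group here can move the number beyond it. A primary amine, a carboxylic acid or a longer chain could test that.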